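The source may hold more compounds than are shown below. What is called first, only, known or untested is meant among the compounds shown, and "the series" means these compounds.

Measured so far:
compound 1, `CC(=O)CC/C=C(\C)CCC1=C(C)CCCC1(C)C`, giving > 15000 nM;
compound 2, `CC1=C(CC/C(C)=C/CC[C@@]2(C)CC[C@@H]([C@H](C)C(=O)O)OO2)C(C)(C)CCC1`, giving > 100000 nM;
compound 3, `C=C1CCCC(C)(C)C1CC[C@@]1(C)CC[C@H]([C@@H](C)C(=O)O)OO1`, giving 8780 nM.

In a functional assay on NCI/ADR-RES cells (Homo sapiens) for inhibition (on this read-out lower numbers stand for stronger inhibition of growth and higher numbers for weaker inhibition of growth), compound 1 returns only a limit, > 15000 nM, and no number. Compound 2 likewise returns only a limit in this assay, > 100000 nM. Among the three values shown, compound 2 stands at the limit of > 100000 nM in this assay, at which 1 of the 3 values shown sits, the weakest reading that can be reported here, while compound 1 stands at the limit of > 15000 nM in this assay, at which 1 of the 3 values shown sits. Within the data shown here, compound 3 is the only one with a number, 8780 nM.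

The next compound, compound 4, `CC1=C(CC/C(C)=C/CC[C@@]2(C)CC[C@H]([C@H](C)C(=O)O)OO2)C(C)(C)CCC1`, keeps everything of compound 2 except one point of configuration: the two compounds have the same atoms and bonds and differ only in configuration as drawn: 1 of 4 stereo elements differ; a stereocentre at a saturated ring carbon is drawn S in compound 2 and R in compound 4. Among the measured compounds shown here, since compound 2 gave only a limit, any real growth inhibition by compound 4 would appear as a move downward; the size of such a move from a change in configuration alone cannot be read from the compounds measured here, and no step between measured compounds is given. The step from compound 2 to compound 4 in this assay is expected to be an at least 4.0-fold lower number from compound 2 to compound 4 (0.60 log units; beyond the scatter), that is, a move toward stronger inhibition. Compound 4 is therefore estimated at 25000 nM, with a range from 8000 nM to 100000 nM.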

Compound 4, concentration for 50% growth inhibition: > 5000 nM
Compound 4: only a limit was reported; the forecaster's own chance of this, stated with the estimate: 40%; the middle value does not contradict the limit.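

Compound 4 gives only a limit in this assay, > 5000 nM. Compound 2 also gives only a limit, > 100000 nM, so no step can be read between these two compounds. From the compounds shown here alone, whether the saturated ring carbon's configuration, drawn S in compound 2 and R in compound 4, changes growth inhibition at all stays open.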